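This account rests on a few compounds, and the source may have more. Where it says the series, first, only, none or still open, it means among the compounds named here.

Measured so far, for antiproliferative activity at a single concentration:

Compound 1 `CC(=O)Nc1nc(-c2cccc(NS(=O)(=O)c3cccc(Br)c3)c2)cs1` — 67.4%
Compound 2 `CC(=O)Nc1nc(-c2cccc(NS(=O)(=O)c3ccc(C#CCO)cc3)c2)cs1` — 99.3%
Compound 3 `CCCCCCC#Cc1cccc(S(=O)(=O)Nc2cccc(-c3csc(NC(C)=O)n3)c2)c1` — 1.2%

In a functional assay on A-375 cells (Homo sapiens) for antiproliferative activity, read by trypan blue exclusion, with a stated time of 48 h, tested at 5 uM (a lower number here means a stronger effect, a higher number a weaker effect of the compound at the concentration tested), compound 3 gives the lowest of the three numbers, 1.2%. The nearest measured compound is compound 1 at 67.4%, the furthest compound 2 at 99.3%, both gaps beyond the scatter. The one step in which a single change is shown, a number 66.2 percentage points lower from compound 1 to compound 3 (beyond the scatter), is large, and the oct-1-yn-1-yl group of compound 3 is at the center of it.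

Compound 4 `CC(=O)Nc1nc(-c2cccc(NS(=O)(=O)c3cccc(C#CCO)c3)c2)cs1` keeps the core of compound 3 and differs from it in one place: hydroxy in place of pentyl on a saturated chain carbon bound to a triple-bonded carbon. The step that bears on this is a number 66.2 percentage points lower from compound 1 to compound 3 (beyond the scatter), which shows how much the octynyl group added to the effect; removing most of its chain and ending it in a hydroxy is therefore expected to give back a good part of that gain. Among the measured compounds shown here, compound 2 also carries a 3-hydroxyprop-1-yn-1-yl group and gives 99.3%, which points the same way, though no single-change step links it to compound 3 or compound 4. The estimated step is a number 83.8 percentage points higher from compound 3 to compound 4 (beyond the scatter), upward and beyond the scatter. Compound 4 is therefore expected to give about 85%, in the range 55% to 100%.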

Compound 4, a percentage reported as activity, at one concentration (the size of the read-out at that concentration, not a potency): 66.2%
For compound 4 the middle estimate is 18.8 percentage points above the measured one; measured number inside the range.
By their numbers in this assay, from the lowest: compound 3; then compounds 4 and 1 (each within the scatter of the next); then compound 2.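

In this assay, the step of a number 65 percentage points higher from compound 3 to compound 4 (beyond the scatter) comes with hexyl giving way to hydroxymethyl, while the triple-bonded carbon stays in place. The effect of compound 3 therefore does not go with the triple bond alone, but with what the chain carries beyond it. The step of a number 1.2 percentage points lower from compound 1 to compound 4 (within the scatter) shows that the bromo and 3-hydroxyprop-1-yn-1-yl groups cannot be told apart at this place in this read-out, and only the oct-1-yn-1-yl group of compound 3 stands out from them. Nothing measured here gives a reason for the difference between the pentyl and hydroxy ends of the chain.

The change from compound 3 to compound 4 shortens the chain and adds a hydroxy in one move, so the compounds shown leave open which of the two goes with the weaker effect. A plain prop-1-yn-1-yl group, a hexyl chain on the triple bond, or an oct-1-yn-1-yl chain ending in a hydroxy or an amine would pull length and end group apart.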